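Benzyl in place of fluoronitrophenoxy on the shared core

The source may hold more compounds than are shown below. What is called first, only, known or untested is meant among the compounds shown, and "the series" means these compounds.

Compound 1, `CC(C)(Oc1ccccc1F)C1OCC(C/C=C\CCC(=O)O)C(c2cccnc2)O1`: in an assay for inhibition of prostacyclin synthase (Homo sapiens), using microsomes (on this read-out higher numbers stand for weaker inhibition and lower numbers for stronger inhibition), compound 1 gives only the limit < 1000 nM.
Compound 2, `COc1ccccc1OC(C)(C)C1OCC(C/C=C\CCC(=O)O)C(c2cccnc2)O1`: compound 2 gives 51000 nM.
Compound 3, `CC(C)(Oc1ccc(F)cc1[N+](=O)[O-])C1OCC(C/C=C\CCC(=O)O)C(c2cccnc2)O1`: compound 3 gives 9000 nM.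

Compound 3 holds the lowest of the two numbers; its nearest neighbour is compound 2, the step being a 5.7-fold lower number from compound 2 to compound 3 (0.75 log units; beyond the scatter), while compound 1 sits at a limit, (the limit of < 1000 nM in this assay, at which 1 of the 3 values shown sits). Compound 4, `CC(C)(Cc1ccccc1)C1OCC(C/C=C\CCC(=O)O)C(c2cccnc2)O1`, carries a group of 7 heavy atoms (7 carbon; one six-membered aromatic ring of carbon only) in place of a group of 11 heavy atoms (6 carbon, 1 nitrogen, 3 oxygen, 1 fluorine; one six-membered aromatic ring of carbon only), on a saturated chain carbon bound to two saturated chain carbons and a saturated ring carbon. The measured steps all kept the oxygen and swapped substituents on the aryl ring: an at least 51-fold higher number from compound 1 to compound 2 (1.70 log units; beyond the scatter) and an at least 9.0-fold higher number from compound 1 to compound 3 (0.95 log units; beyond the scatter). None removed the ether oxygen, so they bear only loosely on this change. The step from compound 3 to compound 4 is therefore expected to be uncertain, a 1.5-fold lower number from compound 3 to compound 4 (0.18 log units; within the scatter). Compound 4 is estimated at 6000 nM, between 1000 nM and 40000 nM.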

Compound 4, half-maximal inhibitory concentration: 13000 nM
For compound 4 the middle estimate is 2.2-fold (0.34 log units) below the measured one; the measured number falls inside the stated range.
By their numbers in this assay, from the lowest: compounds 3 and 4 (each within the scatter of the next); then compound 2. At a limit, below all of these: compound 1.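

Taking out the ether oxygen along with the ring substituents gives no readable shift against the fluoronitrophenoxy group (a 1.4-fold higher number from compound 3 to compound 4 (0.16 log units; within the scatter)), so at this position the oxygen is not required to reach this level. Benzyl still stands apart from 2-methoxyphenoxy (a 3.9-fold lower number from compound 2 to compound 4 (0.59 log units; beyond the scatter)). Against 2-fluorophenoxy the step (an at least 13-fold higher number from compound 1 to compound 4 (1.11 log units; beyond the scatter)) is only a bound, since compound 1 stands at a limit of the assay: the limit of < 1000 nM in this assay, at which 1 of the 4 values shown sits.

The compounds shown do not tell whether a 2-fluorobenzyl group would come close to compound 1. From the compounds shown here alone, how a longer chain such as phenethyl would read also stays open.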